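Swapping Chloro for Hydroxy: Expected Effect on Solubility

This account rests on a few compounds, and the source may have more. Where it says the series, first, only, none or still open, it means among the compounds named here.

Three measured compounds share one core and differ only in the groups on a six-membered aromatic ring of carbon only. Compound 1 `O=[N+]([O-])c1cn2c(n1)OC[C@@H](NCc1ccc(OC(F)(F)F)c(Cl)c1)C2` carries chloro and trifluoromethoxy groups; in a physicochemical assay for solubility, at pH 6.8 (on this read-out lower numbers stand for lower solubility and higher numbers for higher solubility), compound 1 gives 77 ug/mL. Compound 3 `O=[N+]([O-])c1cn2c(n1)OC[C@@H](NCc1ccc(OC(F)(F)F)c(O)c1)C2` has hydroxy in place of that chloro, and in this assay compound 3 gives 56 ug/mL. The step of a 1.4-fold lower number from compound 1 to compound 3 (0.14 log units; within the scatter) is therefore small. Compound 2 `O=[N+]([O-])c1cn2c(n1)OC[C@@H](NCc1ccc(OC(F)(F)F)cc1Cl)C2` carries the same two groups as compound 1, arranged differently on the ring. In this assay compound 2 gives 30 ug/mL; this number sits beyond the scatter below compound 1, while its gap to compound 3 stays within the scatter.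

Compound 4 `O=[N+]([O-])c1cn2c(n1)OC[C@@H](NCc1ccc(OC(F)(F)F)cc1O)C2` has not yet been measured. It differs from compound 2 by hydroxy in place of chloro on an aromatic carbon. Among the compounds with values here, the one measured step that bears on this exchange, a 1.4-fold lower number from compound 1 to compound 3 (0.14 log units; within the scatter), stayed within the scatter. For compound 4 the same exchange of groups is therefore expected to give a 1.2-fold lower number from compound 2 to compound 4 (0.08 log units; within the scatter), with no direction beyond the scatter. Compound 4 is accordingly estimated at 25 ug/mL, with a likely range from 12 ug/mL to 50 ug/mL.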

Compound 4, solubility: 25 ug/mL
The estimate for compound 4 equals the measured number at the digits printed; low and high end bracket the measured number.
By their numbers in this assay, from the lowest: compounds 4, 2, 3 and 1 (each within the scatter of the next, the first and the last beyond it).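

At the aromatic carbon ortho to a large group and meta to a trifluoromethoxy group, hydroxy in place of chloro gives a 1.2-fold lower number from compound 2 to compound 4 (0.08 log units; within the scatter) in this assay and so stays within the scatter. Within the data shown here, the earlier pair showed this exchange at only one place on the ring, with a 1.4-fold lower number from compound 1 to compound 3 (0.14 log units; within the scatter); the new pair adds a second place, and the two steps agree in lying within the scatter even though the exchange brings in 1 hydrogen-bond donor and 1 hydrogen-bond acceptor where chloro has none. No supporting measurement is available to explain why the step at this position is so small.

Two pairs sharing one trifluoromethoxy group cannot show whether the exchange would read the same at the remaining carbons of the ring, or with a methoxy group in place of that trifluoromethoxy group. As far as these compounds go, it also remains open whether a different group at this position, such as an amine or a carboxylic acid, would shift the number beyond the scatter, since only chloro and hydroxy appear there.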